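The source may hold more compounds than are shown below. What is called first, only, known or untested is meant among the compounds shown, and "the series" means these compounds.

Measured so far:
compound 1 `Cc1ccc(NC2=CC(=O)c3c(nc4n3[C@H]3OC[C@@H](O)[C@H]3OC4)C2=O)cc1C` — 4320 nM
compound 2 `O=C1C=C(NC2CCCCC2)C(=O)c2c1nc1n2[C@H]2OC[C@@H](O)[C@H]2OC1` — > 16000 nM

Both values come from a functional assay on HeLa cells (Homo sapiens) for inhibition, read by sulforhodamine B assay; on this read-out higher numbers stand for weaker inhibition and lower numbers for stronger inhibition. Compound 1 gives 4320 nM in this assay. Compound 2 gives only a limit, > 16000 nM; the reading is the assay limit and not a number, so compound 2 stands at the weak end of the two values shown, as noted in the limit of > 16000 nM in this assay, at which 1 of the 2 values shown sits. Among the measured compounds shown here, no pair of measured compounds differs in a single place, so no measured step is available.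

Compound 3 `COc1ccc(NC2=CC(=O)c3nc4n(c3C2=O)[C@H]2OC[C@@H](O)[C@H]2OC4)cc1` is not yet measured. It derives from compound 2 by the change (4-methoxyphenyl in place of cyclohexyl on an amine nitrogen). Compound 1, whose amine nitrogen also bears a six-membered aromatic ring, sits at 4320 nM, well inside the measurable range. The expectation for compound 3 is therefore a step towards stronger inhibition, beyond the usual scatter, though its size cannot be fixed since compound 2 is known only as a limit. The estimated step is an at least 3.2-fold lower number from compound 2 to compound 3 (0.50 log units; beyond the scatter). Compound 3 is estimated at 5000 nM in this assay, with a range from 2000 nM to 13000 nM.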

Compound 3, half-maximal inhibitory concentration: 4780 nM
Estimate against measurement, compound 3: 1.0-fold (0.02 log units) above, and the stated range covers the measured number.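

In this assay, among the compounds shown here, putting 4-methoxyphenyl in place of cyclohexyl on the amine nitrogen gives the only step readable so far at this position: an at least 3.3-fold lower number from compound 2 to compound 3 (0.52 log units; beyond the scatter). On this core, the group on the amine nitrogen therefore decides whether the read-out reaches a number at all, with the aromatic ring giving a measured value and the non-aromatic ring remaining at the limit, although this rests on a single pair. Compound 2 gives > 16000 nM, a limit of the assay and not a number, and the full size of the step stays unfixed because one end of it is that limit: the limit of > 16000 nM in this assay, at which 1 of the 3 values shown sits.

For the compounds shown here, the single change swaps the ring type and adds the methoxy group together, so a phenyl ring without the methoxy group, or an open chain such as butyl on the same amine nitrogen, would be needed to separate the two. Going by these compounds, compound 1 differs from compound 3 in more than one place, so its value cannot be set against this step, and what the dimethylphenyl group contributes on the core of compound 3 stays open.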